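The source may report more compounds than this note shows. Statements on the series, on what has been measured and on what is new or still open speak of the compounds shown alone.

Working notes on the series. Compound 1 `CCC(C)(C)Cc1c[nH]c(CCc2ccc(-n3ncnn3)cc2)n1` bears a 2H-tetrazol-2-yl group on an aromatic carbon of the six-membered ring of carbon only. In a functional assay on HEK293 cells for agonist activity at Bombesin receptor subtype-3 (Mus musculus), read by luminescence and calcium flux, with a stated time of 10 min (on this read-out higher numbers stand for an effect only at larger amounts of compound and lower numbers for an effect already at smaller amounts), compound 1 gives 25 nM, the second highest of the three numbers recorded so far. Compound 2 `CCC(C)(C)Cc1c[nH]c(CCc2ccc(-c3cccc(C#N)n3)cc2)n1` gives 26 nM in this assay, and the step of a 1.0-fold higher number from compound 1 to compound 2 (0.02 log units; within the scatter) lies within the scatter. Compound 3 `CCC(C)(C)Cc1c[nH]c(CCc2ccc(-c3cccc(N)n3)cc2)n1` gives 3.9 nM in this assay; the steps of a 6.4-fold lower number from compound 1 to compound 3 (0.81 log units; beyond the scatter) and a 6.7-fold lower number from compound 2 to compound 3 (0.82 log units; beyond the scatter) are the only ones beyond the scatter, and both end at the 6-aminopyridin-2-yl group of compound 3.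

Compound 4 `CCC(C)(C)Cc1c[nH]c(CCc2ccc(-c3cnsc3)cc2)n1` has not been measured. It differs from compound 1 by 1,2-thiazol-4-yl in place of 2H-tetrazol-2-yl on an aromatic carbon, an exchange of one five-membered aromatic ring for another. Going by the values given here, no measured step exchanges one five-membered ring for another. The closest guidance is a 1.0-fold higher number from compound 1 to compound 2 (0.02 log units; within the scatter), where the tetrazolyl ring was replaced by an aromatic group lacking an amino substituent and the number did not move beyond the scatter. The larger steps of a 6.4-fold lower number from compound 1 to compound 3 (0.81 log units; beyond the scatter) and a 6.7-fold lower number from compound 2 to compound 3 (0.82 log units; beyond the scatter) both arrive with an amino group, which compound 4 does not carry. The expected step in this assay from compound 1 to compound 4 is therefore none beyond the scatter. The estimate for compound 4 is 30 nM, with a range of 10 nM to 100 nM, which is expected to mean a 1.2-fold higher number from compound 1 to compound 4 (0.08 log units; within the scatter).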

Compound 4, half-maximal effective concentration: 6.9 nM
For compound 4 the middle estimate is 4.3-fold (0.64 log units) above the measured one, and the stated range ends above it.
By their numbers in this assay, from the lowest: compounds 3 and 4 (each within the scatter of the next); then compounds 1 and 2 (each within the scatter of the next).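

In this assay the exchange of one five-membered aromatic ring for another, with the same count of heavy atoms, gives a 3.6-fold lower number from compound 1 to compound 4 (0.56 log units; beyond the scatter), so at this place, on an aromatic carbon para to a large group, the ring's hetero atoms alone can move the number beyond the scatter, and the amino group of compound 3 is not required for such a step. Compound 4 also separates from the nitrile-bearing six-membered ring, as a 3.8-fold lower number from compound 2 to compound 4 (0.58 log units; beyond the scatter) shows, while a 1.8-fold higher number from compound 3 to compound 4 (0.25 log units; within the scatter) leaves 1,2-thiazol-4-yl and 6-aminopyridin-2-yl not separated within the scatter, so two quite different rings now share the low end of the series. No measurement at hand accounts for these differences.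

The compounds shown leave open whether the sulfur atom, the single ring nitrogen or the point of attachment of the ring decides the result, which a thiophen-3-yl ring or a 1,3-thiazol-2-yl ring would help to separate. Also open, from the compounds shown here alone, is whether an amino group on the 1,2-thiazol-4-yl ring would shift the number any further.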